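Removing One Methoxy Group: Expected Effect on Cytotoxicity

The source may hold more compounds than are shown below. What is called first, only, known or untested is meant among the compounds shown, and "the series" means these compounds.

Compound 1 `COc1cc(-c2cc(/C=C/C(=O)c3ccc(N)cc3)[nH]n2)cc(OC)c1OC` and compound 2 `COc1ccc(-c2cc(/C=C/C(=O)c3ccc(N)cc3)[nH]n2)cc1OC` differ in a single place: hydrogen in place of methoxy on an aromatic carbon. In a functional assay on SK-MEL-5 cells (Homo sapiens) for cytotoxicity, read by sulforhodamine B assay, with a stated time of 48 h, tested at 0.01 uM (a higher number here means a weaker effect of the compound at the concentration tested, a lower number a stronger effect), compound 1 gives 95%, and compound 2 gives 99%, so the step is a number 4 percentage points higher from compound 1 to compound 2 (within the scatter). Compound 3 `COc1cc(C(=O)/C=C/c2cc(-c3cc(OC)c(OC)c(OC)c3)n[nH]2)cc(OC)c1OC` and compound 4 `COc1ccc(-c2cc(/C=C/C(=O)c3cc(OC)c(OC)c(OC)c3)[nH]n2)cc1OC` are separated by the same change, (hydrogen in place of methoxy on an aromatic carbon), while the difference between the core of compound 3 and the core of compound 1 is not broken down here. In this assay compound 3 gives 96%, close to the values of compound 1 and compound 2. Because the earlier step of a number 4 percentage points higher from compound 1 to compound 2 (within the scatter) remained within the scatter, a similarly small step is expected here, a number 2 percentage points higher from compound 3 to compound 4 (within the scatter). Compound 4 is therefore estimated at 98%, with a likely range from 88% to 105%.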

Compound 4, a percentage reported as activity, at one concentration (the size of the read-out at that concentration, not a potency): 101%
For compound 4 the middle estimate is 3 percentage points below the measured one; low and high end bracket the measured number.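

In this assay, hydrogen in place of methoxy gives a number 5 percentage points higher from compound 3 to compound 4 (within the scatter). The change therefore looks the same on the two cores, with two small steps that do not differ from each other: the same change on two cores in this assay, a number 4 percentage points higher (within the scatter) from compound 1 to compound 2 and a number 5 percentage points higher (within the scatter) from compound 3 to compound 4, 1 percentage points apart, within the scatter of two such steps. Within the data shown here, this shows only that the swap makes no change beyond the scatter on these two cores at this single concentration; it does not show that the same would hold at another concentration or on a third core.

The compounds shown leave open what a different group at this place, such as a hydroxyl or a chlorine atom, would do. They also leave open how a longer chain on that oxygen, such as ethoxy, would read in this assay.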